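The compounds below may be only part of what the source reports. "The series", "measured", "known", "first", "only" and "open" are said of these compounds alone.

Measured so far:
compound 1, `Cc1cc(C)cc(NC(=O)CN2CCC(c3cccc[n+]3[O-])CC2)c1`, with 76%
compound 2, `Cc1cc(NC(=O)CN2CCC(c3cccc[n+]3[O-])CC2)ccc1F`, with 75%
compound 3, `Cc1cccc(Cl)c1NC(=O)CN1CCC(c2ccccn2)CC1`, with 70%

In a functional assay on HEK293 cells for agonist activity at D(4) dopamine receptor (Homo sapiens), read by FLIPR (on this read-out lower numbers stand for smaller maximal responses and higher numbers for larger maximal responses), compound 2 gives the second highest of these three numbers, and its distance to both compound 1 and compound 3 lies within the usual scatter of such measurements. Compound 4, `O=C(CN1CCC(c2cccc[n+]2[O-])CC1)Nc1cc(Cl)cc(Cl)c1`, differs from compound 2 in one place: 3,5-dichlorophenyl in place of 4-fluoro-3-methylphenyl on an amide-type nitrogen. Among the measured compounds shown here, the only measured step that also exchanges the aryl group on the amide nitrogen is a number 1 percentage points lower from compound 1 to compound 2 (within the scatter), a change within the scatter. Compound 3 differs from compound 2 in two places, so its value can only show that it, too, lies close to the others. The exchange leading to compound 4 is therefore expected to give no step beyond the scatter, a number 1 percentage points lower from compound 2 to compound 4 (within the scatter). Compound 4 is estimated at 74%, expected to fall between 60% and 88%.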

Compound 4, largest response reached (reported as efficacy), in percent of the reference or control that the assay uses: 68%
The estimate for compound 4 lay 6 percentage points above the measured number; low and high end bracket the measured number.
By their numbers in this assay, from the lowest: compounds 4, 3, 2 and 1 (each within the scatter of the next).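

In this assay, 3,5-dichlorophenyl on the amide-type nitrogen gives a number 7 percentage points lower from compound 2 to compound 4 (within the scatter) and, set against 3,5-dimethylphenyl, a number 8 percentage points lower from compound 1 to compound 4 (within the scatter). The earlier step compared only rings carrying a methyl group, whereas these two steps show that a ring with two chlorines and no methyl group also leaves the maximal response within the scatter. No available measurement explains these numbers. Still open, going by these compounds, is how the response would look with an amine or a carboxylic acid on this ring, or with a longer chain in place of the ring.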